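Furan for Pyridine: What to Expect in Cytotoxicity

The source may report more compounds than this note shows. Statements on the series, on what has been measured and on what is new or still open speak of the compounds shown alone.

compound 1 `CC1=C(/C=C/C(=O)/C=C/c2ccccc2F)C(C)(C)CCC1`: 11000 nM
compound 2 `CC1=C(/C=C/C(=O)/C=C/c2cccnc2)C(C)(C)CCC1`: 15500 nM

Of the compounds shown here, two have been measured so far. In a functional assay on MCF7 cells (Homo sapiens) for cytotoxicity, read by sulforhodamine B assay, with a stated time of 48 h (on this read-out lower numbers stand for stronger inhibition and higher numbers for weaker inhibition), compound 1 gives 11000 nM, and compound 2 gives 15500 nM. Compound 2 has the higher of the two numbers, but the step from compound 1 to compound 2 is a 1.4-fold higher number from compound 1 to compound 2 (0.15 log units; within the scatter), so the two cannot be told apart on this read-out.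

Compound 3 `CC1=C(/C=C/C(=O)/C=C/c2ccoc2)C(C)(C)CCC1` has not yet been measured. It differs from compound 2 by furan-3-yl in place of pyridin-3-yl on a double-bonded chain carbon bound to a double-bonded chain carbon. Among the measured compounds shown here, only one measured step concerns the same spot: the change from compound 1 to compound 2 also exchanged the ring on that chain carbon, and it gave a 1.4-fold higher number from compound 1 to compound 2 (0.15 log units; within the scatter). A single comparison is thin ground, yet it shows that two quite different rings at this spot returned numbers within the scatter of each other. On that basis the expected step is a 1.1-fold lower number from compound 2 to compound 3 (0.04 log units; within the scatter), meaning no change beyond the scatter in this assay. Compound 3 is therefore estimated at 14000 nM, with a range from 6000 nM to 35000 nM.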

Compound 3, half-maximal inhibitory concentration: 100000 nM
The estimate for compound 3 lay 7.1-fold (0.85 log units) below the measured number; the measured number lies above the stated range.
By their numbers in this assay, from the lowest: compounds 1 and 2 (each within the scatter of the next); then compound 3.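

Among the compounds shown here, the first pair of compounds made this position look tolerant, but the ring on this double-bonded chain carbon does matter in this assay: furan-3-yl in place of pyridin-3-yl gives a 6.5-fold higher number from compound 2 to compound 3 (0.81 log units; beyond the scatter) and so weaker inhibition, and furan-3-yl in place of 2-fluorophenyl gives a 9.1-fold higher number from compound 1 to compound 3 (0.96 log units; beyond the scatter) in the same direction. Among these compounds, then, two rings give numbers within the scatter of each other, while furan-3-yl stands clearly apart on the weak side, so a ring exchange at this spot can be either nearly silent or costly. Nothing in the data at hand gives a reason for this difference.

Furan-3-yl differs from pyridin-3-yl both in ring size and in its hetero atom, oxygen in place of nitrogen, so the compounds shown cannot tell which of the two goes with the step. A thiophene ring would keep the five-membered size with sulfur as the hetero atom, and an aminophenyl group would put an amine on a six-membered ring, so how either would read at this spot remains an open question.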